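The source may hold more compounds than are shown below. What is called first, only, known or untested is meant among the compounds shown, and "the series" means these compounds.

Three compounds share one core and differ only in the group carried on the ring nitrogen. Compound 1 `NS(=O)(=O)N1CCC(C(=O)/C(=N/O)Nc2ccc(F)c(Br)c2)CC1` gives 62500 nM in an assay for inhibition of Tryptophan 2,3-dioxygenase (Homo sapiens), with a stated time of 1 h; on this read-out lower numbers stand for stronger inhibition and higher numbers for weaker inhibition. Compound 2 `O=C(/C(=N/O)Nc1ccc(F)c(Br)c1)C1CCN(C(=O)Nc2ccccc2)CC1` gives 58000 nM, and compound 3 `O=C(/C(=N/O)Nc1ccc(F)c(Br)c1)C1CCN(S(=O)(=O)Nc2ccccc2)CC1` gives 65700 nM. Compound 3 thus has the highest of the three numbers, but its gaps to the others are small: a 1.1-fold higher number from compound 1 to compound 3 (0.02 log units; within the scatter) and a 1.1-fold higher number from compound 2 to compound 3 (0.05 log units; within the scatter), each within the scatter, so the three cannot be ranked against each other.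

Compound 4 `O=C(/C(=N/O)Nc1ccc(F)c(Br)c1)C1CCN(S(=O)(=O)NCc2ccccc2)CC1` is reached from compound 3 by a single change: benzyl in place of phenyl on a sulfonamide nitrogen. The two measured steps that bear on this site are a 1.1-fold higher number from compound 1 to compound 3 (0.02 log units; within the scatter), where a whole phenyl was added to that nitrogen without effect beyond the scatter, and a 1.1-fold higher number from compound 2 to compound 3 (0.05 log units; within the scatter), where the whole group on the ring nitrogen was swapped, again without effect. Every change tried at this end of the molecule has left the number where it was, so a benzyl in place of the phenyl is expected to do the same, giving an estimated step of a 1.0-fold lower number from compound 3 to compound 4 (0.00 log units; within the scatter), no step beyond the scatter in either direction. Compound 4 is therefore estimated at 65000 nM, with a range from 30000 nM to 140000 nM.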

Compound 4, half-maximal inhibitory concentration: > 100000 nM
Compound 4: a limit, no number (the forecaster's own chance of this, stated with the estimate: 10%); at least 1.5-fold (0.18 log units) between middle value and limit.
By their numbers in this assay, from the lowest: compounds 2, 1 and 3 (each within the scatter of the next). At a limit, above all of these: compound 4.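

In this assay compound 4 gives > 100000 nM, which is a limit of the assay and not a number, and it is the only compound shown that sits there: (the limit of > 100000 nM in this assay, at which 1 of the 4 values shown sits). For the compounds shown here, the change from anilino to benzylamino on the sulfonamide nitrogen is thus the only change at this end of the molecule whose result cannot be placed on the scale, whereas compounds 1, 2 and 3 all gave readable numbers within the scatter of each other. Going by these compounds, the comparisons give only floors, an at least 1.5-fold higher number from compound 3 to compound 4 (0.18 log units; that floor lies within the scatter) and an at least 1.6-fold higher number from compound 1 to compound 4 (0.20 log units; that floor lies within the scatter), so the true size of each step is unknown, and this position may be less indifferent to change than compounds 1, 2 and 3 suggested, but a real loss is not proven.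

On these data alone, how far compound 4 truly lies from compound 3 stays unknown, as does whether the benzyl itself matters or any group of this kind would behave alike. A longer chain such as phenethyl, or a benzyl carrying an amine or a carboxylic acid on its ring, would test whether this position responds at all.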